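One Stereocentre Turned Between Compound 2 and Compound 3

The source may report more compounds than this note shows. Statements on the series, on what has been measured and on what is new or still open speak of the compounds shown alone.

Compound 2 `O=C(/C=C\c1ccc(O)cc1)O[C@@H]1[C@H](O[C@H]2CCCC[C@@H]2O)O[C@H](CO)[C@@H](O)[C@H]1O` is the starting point. In a functional assay on A549 cells (Homo sapiens) for cytotoxicity, read by sulforhodamine B assay (a higher number here means a weaker inhibitor, a lower number a stronger inhibitor), compound 2 gives > 10000 nM, which is a limit of the assay and not a number. Going by the values given here, its only measured relative is compound 1 `O=C(/C=C/c1ccc(O)cc1)O[C@H]1[C@H](O[C@H]2CCCC[C@@H]2O)O[C@H](CO)[C@@H](O)[C@@H]1O`. In this assay compound 1 gives > 10000 nM, again a limit rather than a number. The step from a step that the two limits leave unreadable from compound 1 to compound 2 cannot be sized because of the limit of > 10000 nM in this assay, at which 2 of the 2 values shown sit, even though the pair is set apart only by the fact that compounds 1 and 2 differ only in the configuration as drawn.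

Compound 3 `O=C(/C=C\c1ccc(O)cc1)O[C@@H]1[C@H](O[C@@H]2CCCC[C@@H]2O)O[C@H](CO)[C@@H](O)[C@H]1O` is not yet measured. Its relation to compound 2 is this: the two compounds have the same atoms and bonds and differ only in configuration as drawn: 1 of 8 stereo elements differ; a stereocentre at a saturated ring carbon is drawn S in compound 2 and R in compound 3. Among the compounds with values here, the one measured step that bears on such a change of configuration, from compound 1 to compound 2, is itself unreadable, so no direction or size can be drawn from it, and nothing measured speaks against both limits being matched a third time. Compound 3 is therefore expected to give 15000 nM in this assay, within 5000 nM to 50000 nM, and the step from compound 2 to compound 3 is expected to be a step that the limit leaves unreadable from compound 2 to compound 3, most likely reported only as a limit once more.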

Compound 3, half-maximal inhibitory concentration: > 10000 nM
Compound 3 ended at the assay's limit; the forecaster's own chance of this, stated with the estimate: 80%; the middle value does not contradict the limit.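

In this assay compound 3 gives > 10000 nM as its result, which is a limit of the assay and not a number. Going by these compounds alone, no step among compound 1, compound 2 and compound 3 can be read, because all three stand at that same limit: the limit of > 10000 nM in this assay, at which 3 of the 3 values shown sit.

The compounds shown leave open whether any of these changes of configuration alters cytotoxicity at all.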